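Urea nitrogen substituent series: notes toward compound 4

This account rests on a few compounds, and the source may have more. Where it says the series, first, only, none or still open, it means among the compounds named here.

Measured in a functional assay (Pituitary gland cell) with Rattus norvegicus as the target; on this read-out lower numbers stand for an effect already at smaller amounts and higher numbers for an effect only at larger amounts of compound:
- compound 1, `CNC(=O)NCc1ccccc1-c1ccc(CN2C(=O)[C@H](NC(=O)C(C)(C)N)CCc3ccccc32)cc1`: 1 nM
- compound 2, `CCCNC(=O)NCc1ccccc1-c1ccc(CN2C(=O)[C@H](NC(=O)C(C)(C)N)CCc3ccccc32)cc1`: 144 nM
- compound 3, `CC(C)(N)C(=O)N[C@@H]1CCc2ccccc2N(Cc2ccc(-c3ccccc3CNC(=O)NC3CC3)cc2)C1=O`: 45 nM

Compound 3 stands second highest of the three numbers. Its nearest neighbour is compound 2, with a 3.2-fold lower number from compound 2 to compound 3 (0.51 log units; beyond the scatter); its furthest is compound 1, with a 45-fold higher number from compound 1 to compound 3 (1.65 log units; beyond the scatter). All three share the core and differ only in the group on the amide-type nitrogen of the urea.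

Compound 4, `CC(C)(N)C(=O)N[C@@H]1CCc2ccccc2N(Cc2ccc(-c3ccccc3CNC(=O)NCc3ccccc3)cc2)C1=O`, is not yet measured in this assay. It differs from compound 3 by benzyl in place of cyclopropyl on an amide-type nitrogen. Within the data shown here, two measured steps bear on this: a 140-fold higher number from compound 1 to compound 2 (2.16 log units; beyond the scatter) and a 45-fold higher number from compound 1 to compound 3 (1.65 log units; beyond the scatter) both show that replacing the methyl on this nitrogen with a group of more heavy atoms raises the number by a large amount, and a 3.2-fold lower number from compound 2 to compound 3 (0.51 log units; beyond the scatter) shows that propyl and cyclopropyl sit apart by only a modest step, with propyl the higher. Benzyl brings more heavy atoms to this nitrogen than either propyl or cyclopropyl, and nothing measured here points the other way.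

Compound 4 is therefore expected to give a higher number than compound 3, a modest step of a 3.3-fold higher number from compound 3 to compound 4 (0.52 log units; beyond the scatter). The estimate for compound 4 is 150 nM, with a range from 40 nM to 600 nM.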

Compound 4, concentration for half-maximal effect: 390 nM
Beside the measured number, compound 4's estimate is 2.6-fold (0.41 log units) below it, and the stated range covers the measured number.
By their numbers in this assay, from the lowest: compound 1; then compound 3; then compound 2; then compound 4.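

In this assay, cyclopropyl to benzyl on the amide-type nitrogen gives an 8.7-fold higher number from compound 3 to compound 4 (0.94 log units; beyond the scatter), so a ring on this nitrogen does not in itself keep the number low: the six-membered aromatic ring of benzyl ends well above the three-membered ring of cyclopropyl. Benzyl also lies above the open propyl chain, with a 2.7-fold higher number from compound 2 to compound 4 (0.43 log units; beyond the scatter), and the four numbers now rise in the order methyl, cyclopropyl, propyl, benzyl, a ranking of these four groups and nothing wider. Against the methyl group, the change gives a 390-fold higher number from compound 1 to compound 4 (2.59 log units; beyond the scatter), the largest step in the set, which leaves compound 1 clearly apart from the other three and shows that none of the larger groups shown comes close to it.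

No measurement at hand gives a reason for any of these steps. Open, from the compounds shown here alone, is where an ethyl group or the bare amide hydrogen would fall relative to methyl, and whether a pyridylmethyl group or a chain ending in a carboxylic acid would follow the same ranking as benzyl and propyl.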